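Fluoro for Chloro in a Weak Antiproliferative Pair

The source may hold more compounds than are shown below. What is called first, only, known or untested is meant among the compounds shown, and "the series" means these compounds.

Compound 1, `O=C(Nc1ccc(Cl)c(-c2nnc3c(Cl)cccn23)c1)c1ccc(C(F)(F)F)cc1Cl`: in a functional assay on MCF7 cells (Homo sapiens) for antiproliferative activity, read by MTT assay, with a stated time of 72 h (a higher number here means a weaker inhibitor, a lower number a stronger inhibitor), compound 1 gives 81600 nM.
Compound 2, `O=C(Nc1ccc(Cl)c(-c2nnc3c(Cl)cccn23)c1)c1ccc(F)cc1Cl`: in this assay compound 2 reaches only a limit, > 100000 nM.

Among the measured compounds shown here, compound 1 holds the only numerical value shown; the other value is a limit, as the limit of > 100000 nM in this assay, at which 1 of the 2 values shown sits, records. Compound 3, `O=C(Nc1ccc(Cl)c(-c2nnc3c(Cl)cccn23)c1)c1ccc(C(F)(F)F)cc1F`, differs from compound 1 by fluoro in place of chloro on an aromatic carbon. For the measured compounds named here, only one measured step exists, and it concerns a different position: an at least 1.2-fold higher number from compound 1 to compound 2 (0.08 log units; that floor lies within the scatter). With compound 2 at a limit, that step is only a floor. It swaps trifluoromethyl for fluoro rather than chloro for fluoro, so it bears on compound 3 only loosely, showing mainly that compound 1 already lies near the edge of what this assay resolves. With so little to go on, a small step is expected, a 1.2-fold higher number from compound 1 to compound 3 (0.07 log units; within the scatter). Compound 3 may well come back as a limit rather than a number. The estimate for compound 3 is 95000 nM, between 35000 nM and 250000 nM.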

Compound 3, half-maximal inhibitory concentration: 62800 nM
The estimate for compound 3 lay 1.5-fold (0.18 log units) above the measured number, and the stated range covers the measured number.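

Fluoro in place of chloro on this aromatic carbon, ortho to a large group and meta to a trifluoromethyl group, gives a 1.3-fold lower number from compound 1 to compound 3 (0.11 log units; within the scatter). Unlike the earlier step, this one runs between two numbers and can be read in full, and in this assay it does not separate chloro from fluoro at this position. Compound 2 remains a limit and not a number: the limit of > 100000 nM in this assay, at which 1 of the 3 values shown sits.

What the compounds shown leave open is whether any group at this position would give a step beyond the scatter, for instance a methoxy group, an amine or a nitrile, or simply hydrogen. On these data alone, it is also open whether fluoro in place of chloro would read the same way with a group other than trifluoromethyl on the ring.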